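Replacing Chloro with Butylamino on the Shared Core

The source may report more compounds than this note shows. Statements on the series, on what has been measured and on what is new or still open speak of the compounds shown alone.

Compound 1 `CCCCCCCCNc1cnc(C(=O)NCc2ccccc2)cn1` was run in an ADME assay on HeLa cells (Homo sapiens) for cytotoxicity, read by microscopy, with a stated time of 6 days (a higher number here means that more compound is tolerated, a lower number that less compound is tolerated), and gave 100000 nM. Compound 2 `O=C(NCc1ccccc1)c1cnc(Cl)cn1` has no result in this assay, where compound 2 stands as "not determined" (no result reported), so nothing can be said of where it stands. Compound 3 `CCCCNc1cnc(C(=O)NCc2ccccc2)cn1` differs from compound 2 by butylamino in place of chloro on an aromatic carbon. Going by the values given here, no measured step between compounds is available, so the size of the change in this assay cannot be read from data; since compound 1, a close relative, gave 100000 nM, no shift beyond the scatter is expected. Compound 3 is therefore estimated at 100000 nM, with a range from 50000 nM to 200000 nM.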

Compound 3, minimum cytotoxic concentration: > 100000 nM
Compound 3 was reported as a limit; the forecaster's own chance of this, stated with the estimate: 30%; the middle value sits exactly at the limit.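

In this assay, compound 3, with butylamino on the aromatic carbon next to the ring nitrogen, gives > 100000 nM, which is a limit and not a number. Along the chain at this position, the step reads a number no lower from compound 1 to compound 3 (the limit leaves the size open). With this shorter chain, the data therefore show no drop in the concentration tolerated, and the reading rests on a limit: the limit of > 100000 nM in this assay, at which 1 of the 3 values shown sits.

Left open is how far beyond that limit compound 3 lies. As far as these compounds go, it is also open whether a carboxylic acid or a primary amine at this position would lower the concentration tolerated.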